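This account rests on a few compounds, and the source may have more. Where it says the series, first, only, none or still open, it means among the compounds named here.

Of the compounds shown here, two have been measured in a physicochemical assay for lipophilicity; on this read-out lower numbers stand for lower lipophilicity and higher numbers for higher lipophilicity. Compound 1 `CN1CCN(CCCS(=O)(=O)c2ccc3nc(NC(=O)NC(=O)c4cc(-n5cccn5)ccc4Cl)sc3c2)CC1` gives 2 in this assay. Compound 2 `CN1CCC(S(=O)(=O)c2ccc3nc(NC(=O)NC(=O)c4cc(N5CCCC5)ccc4Cl)sc3c2)CC1` gives 3.1, the higher of the two numbers, and its gap to compound 1 lies beyond the usual scatter of the measurement. Compound 3 `CN1CCC(S(=O)(=O)c2ccc3nc(NC(=O)NC(=O)c4cc(-n5cccn5)ccc4Cl)sc3c2)CC1` has not yet been measured in this assay. It is built from compound 2 by a single change: 1H-pyrazol-1-yl in place of pyrrolidin-1-yl on an aromatic carbon. The amine-bearing side chain of compound 2 is kept. Within the data shown here, no measured pair differs only at this position, so the size of the step cannot be read from a direct comparison; compound 1 carries the same 1H-pyrazol-1-yl group but also a different side chain, and its lower number therefore cannot be assigned to the ring exchange alone. The expected step of a number 0.70 log units lower from compound 2 to compound 3 (beyond the scatter) is downward and beyond the scatter, smaller than the gap between compound 1 and compound 2. Compound 3 is accordingly estimated at 2.4 in this assay, within a range from 1.8 to 3.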

Compound 3, distribution coefficient: 2.5
Compound 3: the middle estimate sits 0.10 log units below what was measured; the measured number falls inside the stated range.
By their numbers in this assay, from the lowest: compound 1; then compound 3; then compound 2.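

Among these compounds, with compound 3, the exchange at the aromatic carbon para to the chloro group can be read on its own for the first time: in this assay, 1H-pyrazol-1-yl in place of pyrrolidin-1-yl gives a number 0.60 log units lower from compound 2 to compound 3 (beyond the scatter). The exchange replaces a five-membered non-aromatic ring with a five-membered aromatic ring, with the heavy-atom count unchanged, so a change of ring type alone, with no change in that count, is enough to shift this read-out. Compound 3 also isolates the side chain on the sulfonyl sulfur, where 1-methylpiperidin-4-yl in place of 3-(4-methylpiperazin-1-yl)propyl gives a number 0.50 log units higher from compound 1 to compound 3 (beyond the scatter), showing that this second place also moves the number on its own.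

Nothing shown here explains why the number moves at either place. On these data alone, each step rests on a single pair, so it remains open whether the ring exchange would give a similar step with the 3-(4-methylpiperazin-1-yl)propyl side chain in place, and how other groups at the aromatic carbon, such as morpholin-4-yl, phenyl or a simple methoxy, would compare.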